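Replacing 2-hydroxy-2-methylbutyl with oxolan-2-yl

This account rests on a few compounds, and the source may have more. Where it says the series, first, only, none or still open, it means among the compounds named here.

Compound 1 `CCCCCCC(C)(O)CC(=O)O[C@H](CC=C(C)C)C1=CC(=O)c2c(O)ccc(O)c2C1=O`: > 100000 nM (a limit of the assay, not a number)
Compound 2 `CC(C)=CC[C@@H](OC(=O)C1CCOC1)C1=CC(=O)c2c(O)ccc(O)c2C1=O`: 47500 nM
Compound 3 `CC[C@@](C)(O)CC(=O)O[C@H](CC=C(C)C)C1=CC(=O)c2c(O)ccc(O)c2C1=O`: 12700 nM

In a functional assay on DU-145 cells (Homo sapiens) for cytotoxicity, read by MTT assay (on this read-out lower numbers stand for stronger inhibition and higher numbers for weaker inhibition), compound 3 holds the lower of the two actual numbers, 12700 nM. Compound 4 `CC(C)=CC[C@@H](OC(=O)C1CCCO1)C1=CC(=O)c2c(O)ccc(O)c2C1=O` differs from it by one change: oxolan-2-yl in place of 2-hydroxy-2-methylbutyl on a carbonyl carbon, with oxolan-2-yl in place of 2-hydroxy-2-methylbutyl on a carbonyl carbon. The closest guide is compound 2, which carries oxolan-3-yl at that place. The measured step is a 3.7-fold lower number from compound 2 to compound 3 (0.57 log units; beyond the scatter). The steps of an at least 2.1-fold lower number from compound 1 to compound 2 (0.32 log units; beyond the scatter) and an at least 7.8-fold lower number from compound 1 to compound 3 (0.89 log units; beyond the scatter) start from a limit, so they give only minimum sizes. A modest move back towards compound 2 is therefore expected, and the expected step is a 3.1-fold higher number from compound 3 to compound 4 (0.50 log units; beyond the scatter). For compound 4, the estimate is 40000 nM, with an expected range of 15000 nM to 100000 nM.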

Compound 4, half-maximal inhibitory concentration: 10500 nM
Compound 4: middle estimate off by 3.8-fold (0.58 log units), on the high side; measured number outside the range, below it.
By their numbers in this assay, from the lowest: compounds 4 and 3 (each within the scatter of the next); then compound 2. At a limit, above all of these: compound 1.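

On this carbonyl carbon, oxolan-2-yl and oxolan-3-yl do not behave alike in this assay: the switch gives a 4.5-fold lower number from compound 2 to compound 4 (0.66 log units; beyond the scatter). Oxolan-2-yl also keeps pace with the open 2-hydroxy-2-methylbutyl chain, with a 1.2-fold lower number from compound 3 to compound 4 (0.08 log units; within the scatter), so a ring with no hydrogen-bond donor does as well here as a chain with one. Compound 1 stands at a limit, so an at least 9.5-fold lower number from compound 1 to compound 4 (0.97 log units; beyond the scatter) gives only a minimum size: the limit of > 100000 nM in this assay, at which 1 of the 4 values shown sits.

The compounds shown leave open whether a six-membered oxane ring or a pyrrolidine ring, which carries an amine, would hold this level. They also cannot explain why the two oxolanyl groups differ.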